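Phenoxy in place of methylpiperazinyl on the shared core

This account rests on a few compounds, and the source may have more. Where it says the series, first, only, none or still open, it means among the compounds named here.

The account follows the step from compound 2 to compound 3. In an assay for inhibition of acid-sensing ion channel 3 (Homo sapiens), read by patch clamp, tested at 1 uM (a lower number here means less inhibition, a higher number more inhibition at the concentration tested (going by the name of the read-out)), compound 2, `CN1CCN(c2nc(N)c(C(=O)N=C(N)N)nc2Cl)CC1`, has no single number; its entry reads "not determined" (no result reported). Among the compounds with values here, the only measured value in this assay comes from compound 1, `NC(N)=NC(=O)c1nc(Cl)c(NCC2CCc3ccccc3C2)nc1N`, which gives 44%. Compound 3, `NC(N)=NC(=O)c1nc(Cl)c(Oc2ccccc2)nc1N`, differs from compound 2 in one place: phenoxy in place of 4-methylpiperazin-1-yl on an aromatic carbon. With no value for compound 2, the size and direction of this step cannot be set from the data. Going by compound 1 alone, compound 3 is expected to show inhibition of about 25%, estimated between 0% and 55%.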

Compound 3, a percentage reported as inhibition, at one concentration (the size of the read-out at that concentration, not a potency): 23%
The estimate for compound 3 lay 2 percentage points above the measured number; the range from low to high includes it.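

No step can be read from compound 2 to compound 3: compound 2 has no number to set against compound 3. On these data alone, what swapping 4-methylpiperazin-1-yl for phenoxy does to inhibition stays open, and no evidence bears on this result.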